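A few compounds are considered here, and "the series" means these few. Any claim that something is new, unique, unknown or untested is made for them only; others in the source may bear on it.

Measured so far:
compound 1 `CC(=O)c1ccc(NC(=O)C2CC(O)CN2S(=O)(=O)c2ccc(C)cc2)cc1` gives 12.9% in a functional assay for inhibition, read by spectrophotometry, with a stated time of 20 min, tested at 4 mg/mL; a higher number here means a stronger effect of the compound at the concentration tested, a lower number a weaker effect;
compound 2 `CC(=O)c1ccc(NC(=O)C2CC(O)CN2S(=O)(=O)c2ccc([N+](=O)[O-])cc2)cc1` gives 60.1% in this assay.

Among the measured compounds shown here, compound 2 stands highest of the two numbers; its nearest neighbour is compound 1, the sole measured step being a number 47.2 percentage points higher from compound 1 to compound 2 (beyond the scatter), which is large. Compound 3 `CC(=O)c1ccc(NC(=O)C2CCCN2S(=O)(=O)c2ccc([N+](=O)[O-])cc2)cc1` differs from compound 2 by hydrogen in place of hydroxy on a saturated ring carbon. For the measured compounds named here, that step concerns the aromatic substituent, which compound 3 keeps, so no measured step bears on the change at the saturated ring. The expectation for compound 3 is therefore no step beyond the scatter in this assay, estimated as a number 5.1 percentage points lower from compound 2 to compound 3 (within the scatter). Compound 3 is thus expected near 55%, within 35% to 75%.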

Compound 3, a percentage reported as inhibition, at one concentration (the size of the read-out at that concentration, not a potency): 25.3%
The estimate for compound 3 lay 29.7 percentage points above the measured number; the whole stated range lies above it.
By their numbers in this assay, from the lowest: compound 1; then compound 3; then compound 2.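

Replacing hydroxy with hydrogen on the saturated ring carbon in this assay gives a number 34.8 percentage points lower from compound 2 to compound 3 (beyond the scatter) with the aromatic nitro group unchanged. This position therefore also carries a large step, so the nitro group alone does not secure the read-out of compound 2. No available evidence explains this drop.

Still open, from the compounds shown here alone, is whether methoxy or an amine on this ring carbon would hold the read-out near that of compound 2. Also open, going by these compounds, is whether removing hydroxy has a similar effect with methyl on the aromatic ring.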